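Adding a Second Fluorine to the Sulfonamide Ring

The source may report more compounds than this note shows. Statements on the series, on what has been measured and on what is new or still open speak of the compounds shown alone.

Compound 1 `O=C(NCc1ccc(CNS(=O)(=O)c2ccc(Cl)cc2)cc1)c1ccc(CNc2ncccn2)cc1`: 100 nM
Compound 2 `O=C(NCc1ccc(CNS(=O)(=O)c2ccccc2Cl)cc1)c1ccc(CNc2ncccn2)cc1`: 1000 nM
Compound 3 `O=C(NCc1ccc(CNS(=O)(=O)c2cccc(F)c2)cc1)c1ccc(CNc2ncccn2)cc1`: 1000 nM

In an assay on MDA-MB-231 cells for binding affinity to C-X-C chemokine receptor type 4 (Homo sapiens), read by microscopy, with stated times of 10 min and 30 min (on this read-out higher numbers stand for an effect only at larger amounts of compound and lower numbers for an effect already at smaller amounts), compound 3 sits level with compound 2 at the high end of the three numbers (no change at the digits printed from compound 2 to compound 3 (within the scatter)), while both lie well above compound 1 (a 10-fold higher number from compound 1 to compound 3 (1.00 log units; beyond the scatter)). Compound 4 `O=C(NCc1ccc(CNS(=O)(=O)c2ccc(F)c(F)c2)cc1)c1ccc(CNc2ncccn2)cc1` differs from compound 3 by fluoro in place of hydrogen on an aromatic carbon. Among the measured compounds shown here, the only measured step that bears on this is a 10-fold higher number from compound 1 to compound 3 (1.00 log units; beyond the scatter), where a halogen para to a large group gave the lower number. Compound 4 is therefore expected to move part of the way back toward compound 1, a 2.5-fold lower number from compound 3 to compound 4 (0.40 log units; beyond the scatter), with the lower end of the range still within the scatter of compound 3. Compound 4 is estimated at 400 nM, in the range 120 nM to 1300 nM.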

Compound 4, effective concentration (reported as EC, without a stated level of effect): 100 nM
Compound 4: middle estimate off by 4.0-fold (0.60 log units), on the high side, and the stated range ends above it.
By their numbers in this assay, from the lowest: compounds 1 and 4 (each within the scatter of the next); then compounds 2 and 3 (each within the scatter of the next).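

In this assay fluoro in place of hydrogen, para to a large group, gives a 10-fold lower number from compound 3 to compound 4 (1.00 log units; beyond the scatter) and so shows that one added fluorine at this position is enough to shift the number. The other two steps, a 10-fold lower number from compound 2 to compound 4 (1.00 log units; beyond the scatter) and no change at the digits printed from compound 1 to compound 4 (within the scatter), place 3,4-difluorophenyl level with 4-chlorophenyl, so in these four compounds the lower numbers go with a halogen at this position. No measurement shown here explains the shift.

On these data alone, whether only a halogen does this stays open, since a methoxy group or an amine at this position could behave differently. Also open, as far as these compounds go, is whether 4-fluorophenyl alone would match 3,4-difluorophenyl.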